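A few compounds are considered here, and "the series" means these few. Any claim that something is new, unique, unknown or untested is made for them only; others in the source may bear on it.

Measured compounds in an ADME assay on L6 cells (Rattus norvegicus) for cytotoxicity, read by fluorescence and resazurin assay, with a stated time of 72 h; a higher number here means that more compound is needed for the effect, a lower number that less compound is needed:
compound 1 `O=c1nc(-c2ccccc2)c2cc(-c3cccnc3)ccc2[nH]1` gives > 50000 nM
compound 2 `Cc1cncc(-c2ccc3[nH]c(=O)nc(-c4ccccc4)c3c2)c1` gives > 50000 nM
compound 3 `O=c1nc(-c2ccccc2)c2cc(-c3ccccc3)ccc2[nH]1` gives > 50000 nM

Each of these values is a limit of the assay, not a number. Compound 1 returns only a limit. Compound 2 likewise returns only a limit. Compound 3 returns only a limit. The evidence on all three is the limit of > 50000 nM in this assay, at which 3 of the 3 values shown sit. The steps a step that the two limits leave unreadable from compound 1 to compound 2, a step that the two limits leave unreadable from compound 1 to compound 3 and a step that the two limits leave unreadable from compound 2 to compound 3 are therefore not readable in size. Compound 3 thus stands at the limit, with no number that places it against the other two.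

Compound 4 `O=c1nc(-c2ccccc2)c2cc(-c3ccccc3F)ccc2[nH]1` differs from compound 3 by fluoro in place of hydrogen on an aromatic carbon. The measured steps, methyl in place of hydrogen on an aromatic carbon, phenyl in place of pyridin-3-yl and phenyl in place of 5-methylpyridin-3-yl, each left the value at the limit, so none of them gives a size or direction that can be carried over to a fluoro in place of hydrogen. The expected step that the limit leaves unreadable from compound 3 to compound 4 is accordingly none beyond the scatter, with compound 4 expected to remain at the limit. The estimate for compound 4 is 80000 nM, range 40000 nM to 200000 nM.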

Compound 4, half-maximal effective concentration: 55800 nM
Beside the measured number, compound 4's estimate is 1.4-fold (0.16 log units) above it; the measured number falls inside the stated range.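

No step to compound 4 from compound 1, compound 2 or compound 3 can be read in size, since those three compounds return only a limit: the limit of > 50000 nM in this assay, at which 3 of the 4 values shown sit.

Still open, on these data alone, is where compounds 1, 2 and 3 lie relative to compound 4, and so whether fluoro in place of hydrogen changes the value at all.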